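Stereochemical inversion at the ring carbon in a cyclic amidine series

A few compounds are considered here, and "the series" means these few. Any claim that something is new, unique, unknown or untested is made for them only; others in the source may bear on it.

Working notes on the series. Compound 1 `NC1=NC(CC2=Cc3ccccc3CC2)CO1` is measured in a functional assay for binding affinity to Norepinephrine transporter (Rattus norvegicus), read by radioligand binding, in the presence of a further agent that is not named here (on this read-out higher numbers stand for weaker inhibition and lower numbers for stronger inhibition), and gives 501 nM. Compound 2 `NC1=NCC(CC2=Cc3c(Cl)cccc3CC2)O1` returns only a limit in this assay, namely < 1000 nM; this is the limit described as the limit of < 1000 nM in this assay, at which 1 of the 3 values shown sits, and it is not a number. Going by the values given here, compound 3 `C[C@@]1(C[C@@H]2CN=CN2)CCc2ccccc2C1` gives 200 nM in this assay, the lowest of the two numbers known so far, with compound 1 as its nearest neighbour at a higher number, a gap that lies beyond the usual scatter.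

Compound 4 `C[C@@]1(C[C@H]2CN=CN2)CCc2ccccc2C1` has not yet been measured. It differs from compound 3 as follows: the two compounds have the same atoms and bonds and differ only in configuration as drawn: 1 of 2 stereo elements differ; a stereocentre at a saturated ring carbon is drawn R in compound 3 and S in compound 4. Among the compounds with values here, no comparable pair has been measured, so no step between measured compounds can be called on here. Inversion of configuration at a single saturated ring carbon can move a value in either direction or not at all, and nothing in the known pairs settles this. The estimate for compound 4 is therefore centred near compound 3, leaning slightly toward a weaker value, with a wide range: compound 4 is expected to give 400 nM in this assay, between 100 nM and 2000 nM, and the step from compound 3 to compound 4 is estimated as a 2.0-fold higher number from compound 3 to compound 4 (0.30 log units; within the scatter).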

Compound 4, inhibition constant: 63.1 nM
Compound 4: middle estimate off by 6.3-fold (0.80 log units), on the high side; the whole stated range lies above it.
By their numbers in this assay, from the lowest: compound 4; then compound 3; then compound 1.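

Inverting the saturated ring carbon from R to S gives a 3.2-fold lower number from compound 3 to compound 4 (0.50 log units; beyond the scatter) in this assay, so the configuration at this position changes the read-out by more than the usual scatter. Compounds 1 to 3 could not show this, as no two of them differ in one place only. With atoms and bonds unchanged, the step can be assigned to this single stereocentre: the fact that compounds 3 and 4 differ only in the configuration as drawn

From the compounds shown here alone, what the second stereocentre contributes remains open, as it is drawn the same way in compound 3 and compound 4. Also open, going by these compounds, is whether the lower number with the S configuration would persist with a longer chain or a carboxylic acid in place of the methyl group on the shared core.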